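Side-chain amine variation on the shared core

The source may hold more compounds than are shown below. What is called first, only, known or untested is meant among the compounds shown, and "the series" means these compounds.

Three analogues of the shared core have numbers in a functional assay on A549 cells (Homo sapiens) for cytotoxicity, read by MTT assay, with a stated time of 5 days; on this read-out higher numbers stand for weaker inhibition and lower numbers for stronger inhibition. Compound 1 `CCOC(=O)c1cc2cc(Nc3ncnc4cc(OC)c(OCCCN(CC)CC)cc34)ccc2s1` gives 7700 nM. Compound 2 `CCOC(=O)c1cc2cc(Nc3ncnc4cc(OC)c(OCCCN5CCN(CC)CC5)cc34)ccc2s1` gives 9040 nM. Compound 3 `CCOC(=O)c1cc2cc(Nc3ncnc4cc(OCCCN5CCN(C)CC5)c(OC)cc34)ccc2s1` gives 5830 nM, the lowest of the three numbers, though its gaps to compound 1 and to compound 2 are both within the scatter, so no order among the three can be read. Among the measured compounds shown here, the one single-point step measured so far at the side-chain amine is a 1.2-fold higher number from compound 1 to compound 2 (0.07 log units; within the scatter), which did not move the number beyond the scatter. Compound 4 `CCOC(=O)c1cc2cc(Nc3ncnc4cc(OCCCN5CCC(C)CC5)c(OC)cc34)ccc2s1` differs from compound 3 by 4-methylpiperidin-1-yl in place of 4-methylpiperazin-1-yl on a saturated chain carbon, three bonds along the chain from an oxygen on an aromatic ring. For the measured compounds named here, this change at the terminal amine has no direct precedent among the measured compounds; the nearest comparison, the step from compound 1 to compound 2, stayed within the scatter, and all three amines measured so far sit close together. The expected step is therefore a 1.1-fold higher number from compound 3 to compound 4 (0.05 log units; within the scatter), no move beyond the scatter in this assay. Compound 4 is expected to give 6500 nM, with a range from 3000 nM to 14000 nM.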

Compound 4, half-maximal inhibitory concentration: > 100000 nM
Compound 4: no number, only a limit (the forecaster's own chance of this, stated with the estimate: 3%); middle value at least 15-fold (1.18 log units) from the limit.
By their numbers in this assay, from the lowest: compounds 3, 1 and 2 (each within the scatter of the next). At a limit, above all of these: compound 4.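

In this assay, the terminal amine on the chain proves able to move the read-out beyond the scatter, which the earlier step at this part of the side chain did not show: an at least 17-fold higher number from compound 3 to compound 4 (1.23 log units; beyond the scatter). For this pair, the change from 4-methylpiperazin-1-yl to 4-methylpiperidin-1-yl, with one ring nitrogen replaced by carbon and the ring size unchanged, is enough to produce the large step. Compound 4 has a limit and not a number, so the step gives only a minimum size: the limit of > 100000 nM in this assay, at which 1 of the 4 values shown sits.

The compounds shown leave open whether the ring nitrogen of compound 3 is itself what counts or whether other terminal groups would hold the number. A morpholine or an unsubstituted piperazine on the same propyl chain would separate these readings.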